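Cytotoxicity of nitrofuran amides: adding a cyclopropylcarbonylamino group

A few compounds are considered here, and "the series" means these few. Any claim that something is new, unique, unknown or untested is made for them only; others in the source may bear on it.

Measured so far in an ADME assay on Vero cells (Chlorocebus sabaeus) for cytotoxicity, read by MTT assay, with a stated time of 72 h; on this read-out lower numbers stand for stronger inhibition and higher numbers for weaker inhibition:
compound 1 `O=C(Nc1nc(-c2ccccc2)cs1)c1ccc([N+](=O)[O-])o1`: 41700 nM
compound 2 `COc1cccc(-c2csc(NC(=O)c3ccc([N+](=O)[O-])o3)n2)c1`: 58700 nM
compound 3 `CC(C)(C)OC(=O)Nc1cccc(-c2csc(NC(=O)c3ccc([N+](=O)[O-])o3)n2)c1`: "not determined" (no result reported)

Compound 1 gives the lowest of the two numbers that were obtained, and compound 2 sits close to it: the step of a 1.4-fold higher number from compound 1 to compound 2 (0.15 log units; within the scatter) lies within the usual scatter of repeated runs. Compound 3 carries a further variation on the same ring but was not measured.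

Compound 4 `O=C(Nc1nc(-c2cccc(NC(=O)C3CC3)c2)cs1)c1ccc([N+](=O)[O-])o1` differs from compound 1 by one change: (cyclopropylcarbonyl)amino in place of hydrogen on an aromatic carbon. Within the data shown here, the only measured step that bears on a change at this position is the one from compound 1 to compound 2, which put a methoxy group in place of hydrogen on the same aromatic carbon and moved the number only within the scatter. That step gives no sign of a strong effect, so compound 4 is expected to land close to compound 1, with the step of a 1.2-fold higher number from compound 1 to compound 4 (0.08 log units; within the scatter) expected to stay within the scatter. Compound 4 is therefore estimated at 50000 nM, with a likely range from 20000 nM to 120000 nM.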

Compound 4, half-maximal inhibitory concentration: 35700 nM
The estimate for compound 4 lay 1.4-fold (0.15 log units) above the measured number; low and high end bracket the measured number.
By their numbers in this assay, from the lowest: compounds 4, 1 and 2 (each within the scatter of the next).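

In this assay, the earlier methoxy step left open whether a bigger group on this aromatic carbon would shift the number, and (cyclopropylcarbonyl)amino, with 6 heavy atoms and a three-membered ring, gives a 1.2-fold lower number from compound 1 to compound 4 (0.07 log units; within the scatter). Exchanging methoxy for this group gives a 1.6-fold lower number from compound 2 to compound 4 (0.22 log units; within the scatter), so hydrogen, methoxy and (cyclopropylcarbonyl)amino at this place cannot be told apart in this read-out, even though the new group brings a hydrogen-bond donor and a hydrogen-bond acceptor. No supporting data are available to explain this lack of a clear difference.

On these data alone, whether an amine or a carboxylic acid on this carbon would move the number beyond the scatter remains open. So does whether a longer chain in place of the cyclopropyl ring would leave it unchanged.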